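Chloro Added to a Rearranged Core

A few compounds are considered here, and "the series" means these few. Any claim that something is new, unique, unknown or untested is made for them only; others in the source may bear on it.

Three compounds have been measured in an assay on U2OS cells for activation of nuclear factor erythroid 2-related factor 2 (Homo sapiens), read by beta-arrestin recruitment, with a stated time of 6 h; on this read-out higher numbers stand for an effect only at larger amounts of compound and lower numbers for an effect already at smaller amounts:
Compound 1 `O=S(=O)(/C=C/c1ccccn1)c1cccc(F)c1` gives 1680 nM.
Compound 2 `O=S(=O)(/C=C/c1ccc(Cl)cn1)c1cccc(F)c1` gives 2500 nM.
Compound 3 `O=S(=O)(/C=C/c1cccnc1)c1ccccc1F` gives 6860 nM.

Compound 2 differs from compound 1 by chloro in place of hydrogen on an aromatic carbon and the step of a 1.5-fold higher number from compound 1 to compound 2 (0.17 log units; within the scatter) is small. Compound 3 has the same atoms as compound 1, joined differently; the difference between the two cores is not broken down here, and compound 3 gives the highest number of the three. Compound 4 `O=S(=O)(/C=C/c1cccnc1Cl)c1ccccc1F` differs from compound 3 by chloro in place of hydrogen on an aromatic carbon, the same kind of change, though here the chloro sits next to the ring nitrogen and ortho to a large group rather than two atoms from the ring nitrogen and para to a large group. The step of a 1.3-fold higher number from compound 3 to compound 4 (0.12 log units; within the scatter) is expected to resemble the earlier one because a 1.5-fold higher number from compound 1 to compound 2 (0.17 log units; within the scatter) stayed within the scatter. Compound 4 is therefore estimated at 9000 nM, between 4000 nM and 20000 nM.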

Compound 4, half-maximal effective concentration: 217 nM
Estimate against measurement, compound 4: 41-fold (1.62 log units) above; the measured number lies below the stated range.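

On the core of compound 3, chloro in place of hydrogen gives a 32-fold lower number from compound 3 to compound 4 (1.50 log units; beyond the scatter), and the same kind of change on the core of compound 1 does not give a matching result: the same change on two cores in this assay, a 1.5-fold higher number (0.17 log units; within the scatter) from compound 1 to compound 2 and a 32-fold lower number (1.50 log units; beyond the scatter) from compound 3 to compound 4, 47-fold (1.67 log units) apart, beyond the scatter of two such steps. This shows that the size of this step in this assay cannot be assumed to carry over from one core to the other in this series. It does not show whether the core itself accounts for the gap, since the chloro also sits in a different place in each pair.

Still open, going by these compounds, is whether chloro next to the ring nitrogen and ortho to a large group would give a similar step on the core of compound 1. Also open, on these data alone, is whether a methoxy group or an amine in that place would behave like chloro.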